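The source may hold more compounds than are shown below. What is called first, only, known or untested is meant among the compounds shown, and "the series" means these compounds.

Values measured so far in a functional assay on ECa-109 cells for inhibition, with ECa-109 cell line (Homo sapiens) as the target, read by MTT assay, with a stated time of 48 h (a lower number here means a stronger inhibitor, a higher number a weaker inhibitor), are as follows.

- compound 1 `COc1ccc(-c2coc3cc(OCCCSC(=S)N4CCN(C(C)=O)CC4)ccc3c2=O)cc1` gives 24700 nM
- compound 2 `COc1ccc(-c2coc3cc(OCCCSC(=S)N4CCN(c5ccccn5)CC4)ccc3c2=O)cc1` gives 38300 nM
- compound 3 `COc1ccc(-c2coc3cc(OCCCSC(=S)N4CCCC4)ccc3c2=O)cc1` gives 30800 nM

Compound 3 lies within the scatter of both other compounds, so no order among the three can be read from these numbers.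

The next compound is compound 4 `COc1ccc(-c2coc3cc(OCCCSC(=S)N4CCOCC4)ccc3c2=O)cc1` and its change from compound 3 is morpholin-4-yl in place of pyrrolidin-1-yl on a thiocarbonyl carbon with morpholin-4-yl in place of pyrrolidin-1-yl on a thiocarbonyl carbon. Going by the values given here, no measured compound yet carries morpholin-4-yl. The bearing steps are a 1.2-fold higher number from compound 1 to compound 3 (0.10 log units; within the scatter) and a 1.2-fold lower number from compound 2 to compound 3 (0.09 log units; within the scatter) as both exchange the group on this thiocarbonyl carbon, and a 1.6-fold higher number from compound 1 to compound 2 (0.19 log units; within the scatter) also stays small. None of them leaves the scatter, so no step beyond the scatter is expected in this assay here. The expected step is a 1.0-fold lower number from compound 3 to compound 4 (0.01 log units; within the scatter) and this is only an estimate. The estimate for compound 4 is 30000 nM with an expected range from 16000 nM to 56000 nM in this series.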

Compound 4, half-maximal inhibitory concentration: 34000 nM
Beside the measured number, compound 4's estimate is 1.1-fold (0.05 log units) below it; the range from low to high includes it.
By their numbers in this assay, from the lowest: compounds 1, 3, 4 and 2 (each within the scatter of the next).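

In this assay the swap of the five-membered ring for the six-membered morpholin-4-yl, with its second hetero atom, gives a 1.1-fold higher number from compound 3 to compound 4 (0.04 log units; within the scatter) and stays within the scatter. Morpholin-4-yl also sits close to both piperazines, with a 1.1-fold lower number from compound 2 to compound 4 (0.05 log units; within the scatter) for 4-(pyridin-2-yl)piperazin-1-yl and a 1.4-fold higher number from compound 1 to compound 4 (0.14 log units; within the scatter) for 4-acetylpiperazin-1-yl, so all four groups on this thiocarbonyl carbon remain within the scatter of one another and none of the four compounds goes against this. Nothing at hand gives a reason for this flat picture.

Open, from the compounds shown here alone, is whether an open-chain amine such as diethylamine on the thiocarbonyl carbon, or a longer chain linking the shared core to the sulfur, would move the number beyond the scatter. Going by these compounds, all four values also come from one cell line, so whether the flat picture holds in other cells stays open.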